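Heteroaryl thioether variation on a hexylurea series

The compounds below may be only part of what the source reports. "The series", "measured", "known", "first", "only" and "open" are said of these compounds alone.

Among the measured compounds shown here, all three compounds measured so far share one urea core and differ only in the aromatic group on the sulfur. Compound 1 `CCCCCCN(CCCCCSc1nc2ccccc2s1)C(=O)Nc1ccc(F)cc1F` gives 2730 nM in an assay on cells (Macrophage) for inhibition of sterol O-acyltransferase 1 (Mus musculus); on this read-out higher numbers stand for weaker inhibition and lower numbers for stronger inhibition. Compound 2 `CCCCCCCN(CCCCCSc1ncccn1)C(=O)Nc1ccc(F)cc1F` gives 4370 nM in this assay, the second highest of the three numbers; compound 3 `CCCCCCCN(CCCCCSc1nnc(-c2ccccc2)n1-c1ccccc1)C(=O)Nc1ccc(F)cc1F` gives 4800 nM there, and both of its gaps to the other compounds lie within the scatter, so the three values cannot be ordered. Compound 4 `CCCCCCCN(CCCCCSc1n[nH]c(-c2ccccc2)n1)C(=O)Nc1ccc(F)cc1F` differs from compound 2 by 5-phenyl-1H-1,2,4-triazol-3-yl in place of pyrimidin-2-yl on a sulfur. Since compound 3 carries the same triazole core and its value sits within the scatter of compound 2, a step from compound 2 to compound 4 of a 1.2-fold lower number from compound 2 to compound 4 (0.10 log units; within the scatter) is expected, meaning none beyond the scatter. Compound 4 is estimated at 3500 nM, within 1500 nM to 8500 nM.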

Compound 4, half-maximal inhibitory concentration in the sterol O-acyltransferase 1 assay: 4180 nM
Compound 4: the middle estimate sits 1.2-fold (0.08 log units) below what was measured; measured number inside the range.
By their numbers in the sterol O-acyltransferase 1 assay, from the lowest: compounds 1, 4, 2 and 3 (each within the scatter of the next).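

At this place on the sulfur, the sterol O-acyltransferase 1 assay shows no response to 5-phenyl-1H-1,2,4-triazol-3-yl in place of pyrimidin-2-yl: a 1.0-fold lower number from compound 2 to compound 4 (0.02 log units; within the scatter). The read-out therefore stays within the scatter even though 11 heavy atoms enter for 6 and a hydrogen-bond donor is added. In a physicochemical assay for lipophilicity (a higher number here means a more lipophilic compound, a lower number a more polar compound), the same change is large, with compound 2 at 5.41 and compound 4 at 6.78 so that a clear rise in lipophilicity comes without a matching change in inhibition: the measured partition coefficient of compound 2, 5.41, and of compound 4, 6.78, a number 1.37 log units higher (beyond the scatter)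

On these data alone, it remains open whether any group on the sulfur moves the inhibition number beyond the scatter. An aromatic group carrying a carboxylic acid, for example, would test whether lower lipophilicity changes it.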